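The source may report more compounds than this note shows. Statements on the series, on what has been measured and on what is new or still open speak of the compounds shown alone.

Measured compounds in an ADME assay on HepG2 cells (Homo sapiens) for cytotoxicity, read by CellTiter-Glo and resazurin assay, with a stated time of 72 h; a higher number here means that more compound is needed for the effect, a lower number that less compound is needed:
Compound 1, `CC(C)N(Cc1cccc(OCCCCCC(=O)O)c1)C(=O)c1ccc(-c2ccoc2)cc1`, gives only the assay limit > 26000 nM.
Compound 2, `CC(C)N(Cc1cccc(OCCCCCC(=O)O)c1)C(=O)c1ccc(-c2cc3ccccc3n2S(=O)(=O)c2ccccc2)cc1`, gives only the assay limit > 26000 nM.
Compound 3, `CCOC(=O)CCCCCOc1cccc(CN(C(=O)c2ccc(-c3ccoc3)cc2)C(C)C)c1`, gives only the assay limit > 26000 nM.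

Compound 3 thus stands at the limit of this assay, and the two further values shown are limits as well; no numbered value exists anywhere in the series. For the measured compounds named here, the single step between measured compounds, a step that the two limits leave unreadable from compound 1 to compound 3, is unreadable for the same reason, and it concerns a different place in the molecule. The unmeasured compound 4, `CCOC(=O)CCCCCOc1cccc(CN(C(=O)c2ccc(-c3cccc(S(C)(=O)=O)c3)cc2)C(C)C)c1`, differs from compound 3 in one place: 3-(methylsulfonyl)phenyl in place of furan-3-yl on an aromatic carbon. Going by the values given here, no measured step bears on an exchange of this kind, so the only guide is the limit of > 26000 nM in this assay, at which 3 of the 3 values shown sit, at which every value of the series sits. Compound 4 is therefore expected to show no step beyond the scatter in this assay, a step that the limit leaves unreadable from compound 3 to compound 4. For compound 4 the estimated value in this assay is 30000 nM, with a range from 13000 nM to 70000 nM, and most likely only a limit will again be reported.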

Compound 4, half-maximal effective concentration: > 26000 nM
Compound 4: only a limit was reported (the forecaster's own chance of this, stated with the estimate: 85%); the middle value does not contradict the limit.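

Compound 4, like compound 3, gives only a limit, so no step between compound 3 and compound 4 can be read in this assay: the limit of > 26000 nM in this assay, at which 4 of the 4 values shown sit.

The compounds shown leave open whether 3-(methylsulfonyl)phenyl in place of furan-3-yl, or any other change among them, alters cytotoxicity at all.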